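Replacing cyclopentyl with 4-fluorophenyl in compound 2

The source may hold more compounds than are shown below. What is called first, only, known or untested is meant among the compounds shown, and "the series" means these compounds.

In a functional assay on MV4-11 cells (Homo sapiens) for antiproliferative activity, read by CellTiter-Glo, with a stated time of 72 h (on this read-out higher numbers stand for weaker inhibition of growth and lower numbers for stronger inhibition of growth), compound 1 `COCCN[C@H]1CC[C@H](Nc2cc(-c3csc(SCC4CCOCC4)n3)c(Cl)cn2)CC1` gives 340 nM, while compound 2 `COCCN[C@H]1CC[C@H](Nc2cc(-c3csc(NCC4CCCC4)n3)c(Cl)cn2)CC1` gives 2160 nM, the higher of the two numbers. Compound 3 `COCCN[C@H]1CC[C@H](Nc2cc(-c3csc(NCc4ccc(F)cc4)n3)c(Cl)cn2)CC1` differs from compound 2 by one change: 4-fluorophenyl in place of cyclopentyl on a saturated chain carbon bound to a nitrogen on an aromatic ring. Within the data shown here, the only measured step, a 6.4-fold higher number from compound 1 to compound 2 (0.80 log units; beyond the scatter), came from a different swap. It shows that a swap in this part of the molecule can move the number, but it gives no direction for the new change, so no shift beyond the scatter is expected. The expected step is a 1.2-fold lower number from compound 2 to compound 3 (0.08 log units; within the scatter). For compound 3, the estimated value is 1800 nM, within an expected range of 600 nM to 5000 nM.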

Compound 3, concentration for 50% growth inhibition: 880 nM
Estimate against measurement, compound 3: 2.0-fold (0.31 log units) above; measured number inside the range.
By their numbers in this assay, from the lowest: compound 1; then compound 3; then compound 2.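

In this assay, 4-fluorophenyl in place of cyclopentyl gives a 2.5-fold lower number from compound 2 to compound 3 (0.39 log units; beyond the scatter), so the ring on this saturated chain carbon bound to a nitrogen on an aromatic ring can itself shift the number. Even so, (4-fluorobenzyl)amino does not match ((oxan-4-yl)methyl)sulfanyl, with a 2.6-fold higher number from compound 1 to compound 3 (0.41 log units; beyond the scatter). Nothing available explains either step. Still open, as far as these compounds go, is whether the fluorine matters, which a plain benzyl group would test. A (4-fluorobenzyl)sulfanyl group would show whether this ring and the sulfur linker can be combined.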